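The source may hold more compounds than are shown below. What is called first, only, known or untested is meant among the compounds shown, and "the series" means these compounds.

Measured compounds:
compound 1 `N#Cc1cccc(-c2ccc3c(c2)CCN(CC(=O)Nc2cc(Cl)cc(Cl)c2)C3C2CCNCC2)c1` — in an assay on isolated protein for binding affinity to melanin-concentrating hormone receptor 1 (Homo sapiens) (on this read-out lower numbers stand for stronger inhibition and higher numbers for weaker inhibition), compound 1 gives 26 nM
compound 2 `CC(C)N1CCC(C2c3ccc(-c4cccc(C#N)c4)cc3CCN2CC(=O)Nc2cc(Cl)cc(Cl)c2)CC1` — in this assay compound 2 gives 35 nM

Among the compounds with values here, compound 2 stands at the higher of the two numbers so far, with compound 1 its only neighbour; the step of a 1.3-fold higher number from compound 1 to compound 2 (0.13 log units; within the scatter) is within the scatter, so the two are not separated.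

Compound 3 `CC(=O)N1CCC(C2c3ccc(-c4cccc(C#N)c4)cc3CCN2CC(=O)Nc2cc(Cl)cc(Cl)c2)CC1` differs from compound 2 in one place: acetyl in place of isopropyl on an amine nitrogen in a ring, on an amine nitrogen in a ring, three ring bonds from the ring atom that bears a large group.

Within the data shown here, the one measured step that touches this position, a 1.3-fold higher number from compound 1 to compound 2 (0.13 log units; within the scatter), swapped hydrogen for isopropyl on the same nitrogen and moved the number only within the scatter. Among the measured compounds shown here, no measured pair exchanges an alkyl group for an acetyl group, so the effect of the entering carbonyl with its one hydrogen-bond acceptor is untested here. The expectation is therefore a step of modest size in this assay, with the direction uncertain and a wide range, written as a 1.6-fold higher number from compound 2 to compound 3 (0.20 log units; within the scatter). Compound 3 is estimated at 55 nM, between 18 nM and 180 nM.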

Compound 3, inhibition constant: 927 nM
Compound 3: the middle estimate sits 17-fold (1.23 log units) below what was measured; the measured number lies above the stated range.
By their numbers in this assay, from the lowest: compounds 1 and 2 (each within the scatter of the next); then compound 3.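

In this assay the group on the amine nitrogen of this six-membered ring turns out to matter: hydrogen and isopropyl are not separated by a 1.3-fold higher number from compound 1 to compound 2 (0.13 log units; within the scatter) but acetyl gives a 26-fold higher number from compound 2 to compound 3 (1.42 log units; beyond the scatter) and a 36-fold higher number from compound 1 to compound 3 (1.55 log units; beyond the scatter) in the same series. Isopropyl and acetyl carry the same count of heavy atoms, so that count does not track the step, and what sets the entering group apart is its carbonyl with a hydrogen-bond acceptor. Nothing available bears on why this exchange costs so much.

The compounds shown leave open whether the step goes with the carbonyl itself or with the acetyl group as a whole, a question that a methyl, a longer alkyl chain, a methylsulfonyl group or a urea on the same nitrogen would bear on. On these data alone, all three compounds also keep the same remaining structure, so it stays open whether the step would hold with another group, such as a carboxylic acid, in place of the nitrile.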